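A Methyl Added to an Amine Nitrogen

The compounds below may be only part of what the source reports. "The series", "measured", "known", "first", "only" and "open" are said of these compounds alone.

Compound 1 `CNCC(=O)Nc1cc(OC)ccc1C(=O)c1cc(OC)c(OC)c(OC)c1` gives 610 nM
Compound 2 `C=C(c1ccc(OC)cc1NC(=O)CO)c1ccc(OC)c2c1C=CC(C)(C)O2` gives 70 nM

In a functional assay on A549 cells (Homo sapiens) for antiproliferative activity, read by MTT assay, with a stated time of 48 h (on this read-out higher numbers stand for weaker inhibition and lower numbers for stronger inhibition), compound 1 gives 610 nM and so holds the higher of the two numbers, which marks it as the weaker inhibitor of the pair. Compound 2 at 70 nM lies lower, by a gap beyond the usual scatter. These two compounds differ in more than one place, so their gap cannot be tied to any single change.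

Compound 3 `COc1ccc(C(=O)c2cc(OC)c(OC)c(OC)c2)c(NC(=O)CN(C)C)c1` has not been measured yet. It keeps the core of compound 1 and carries methyl in place of hydrogen on an amine nitrogen so that methylamino becomes dimethylamino. Among the measured compounds shown here, no measured pair shows this change, so the data do not reveal its effect. The expectation therefore starts from compound 1 at 610 nM and rests on how small the change is. In this assay no shift beyond the scatter is expected, and the estimated 1.2-fold lower number from compound 1 to compound 3 (0.09 log units; within the scatter) is expected to be minor. Compound 3 is estimated at 500 nM with an expected range from 150 nM to 1800 nM as its likely span.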

Compound 3, half-maximal inhibitory concentration: 590 nM
For compound 3 the middle estimate is 1.2-fold (0.07 log units) below the measured one, and the stated range covers the measured number.
By their numbers in this assay, from the lowest: compound 2; then compounds 3 and 1 (each within the scatter of the next).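

In this assay, among the compounds shown here, the step from methylamino to dimethylamino reads a 1.0-fold lower number from compound 1 to compound 3 (0.01 log units; within the scatter) and is the first comparison here between compounds that differ in only one place. It shows that this amine nitrogen, whose other neighbours are saturated chain carbons, accepts a methyl in place of its hydrogen without any shift this assay can separate from the usual scatter, so on the core of compound 1 the hydrogen on this nitrogen is not needed for the antiproliferative read-out. Nothing measured here accounts for why the two compounds read alike.

Going by these compounds, a single added methyl is a very small probe, so it remains open whether this nitrogen would accept larger groups, such as an ethyl or a longer chain, or a ring that takes in the nitrogen, such as a morpholine or a piperidine. On these data alone, it is equally open what would follow from replacing the amine with a carboxylic acid, or from making the same methyl change on a different core, since one pair in one cell line cannot show how far this result extends.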